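The compounds below may be only part of what the source reports. "The series", "measured", "known", "first", "only" and "open" are said of these compounds alone.

Measured compounds in the series:

Compound 1 `O=c1[nH]cnc2c1c(-c1ccoc1)cn2[C@@H]1O[C@H](CO)[C@@H](O)[C@H]1O`. In a functional assay on CEM-DNR-bulk cells (Homo sapiens), read by MTT assay, with a stated time of 72 h (a higher number here means a weaker inhibitor, a lower number a stronger inhibitor), compound 1 gives > 20000 nM, which is a limit of the assay and not a number.
Compound 2 `COc1ncnc2c1c(-c1ccoc1)cn2[C@@H]1O[C@H](CO)[C@@H](O)[C@H]1O`. In this assay compound 2 gives > 20000 nM, again a limit of the assay.
Compound 3 `O=c1[nH]cnc2c1c(-c1cccs1)cn2[C@@H]1O[C@H](CO)[C@@H](O)[C@H]1O`. In this assay compound 3 gives > 20000 nM, also a limit of the assay.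

Compound 4 `COc1ncnc2c1c(-c1cccs1)cn2[C@@H]1O[C@H](CO)[C@@H](O)[C@H]1O` has not yet been measured in this assay.

Compound 1 and compound 2 carry different cores; the difference between the two cores is not broken down here. Compound 3 arises from compound 1 by thiophen-2-yl in place of furan-3-yl on an aromatic carbon. The corresponding step in this assay, a step that the two limits leave unreadable from compound 1 to compound 3, cannot be read, since the limit of > 20000 nM in this assay, at which 3 of the 3 values shown sit: both ends sit at a limit, and no ordering between compound 1 and compound 3 can be stated.

Compound 4 arises from compound 2 by thiophen-2-yl in place of furan-3-yl on an aromatic carbon. The place of the change is described in the same words for both pairs, so this is the same change as from compound 1 to compound 3, now made on the core of compound 2.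

For compound 4 the step that the limit leaves unreadable from compound 2 to compound 4 in this assay is expected to be unresolved in the same way, resting on (the limit of > 20000 nM in this assay, at which 3 of the 3 values shown sit), where every value in the series sits. The estimate for compound 4 in this assay is 30000 nM. The expected range for compound 4 runs from 12000 nM to 100000 nM, and a limit rather than a number is the likelier outcome.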

Compound 4, half-maximal inhibitory concentration: 12100 nM
Compound 4: the middle estimate sits 2.5-fold (0.39 log units) above what was measured; measured number inside the range.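

In this assay, among these compounds, thiophen-2-yl in place of furan-3-yl on an aromatic carbon of the core of compound 2 gives an at least 1.6-fold lower number from compound 2 to compound 4 (0.21 log units; that floor lies within the scatter), and compound 4, at 12100 nM, is the only compound with a number. The same change on the core of compound 1 cannot be read, since both of its ends are limits, so the series neither confirms nor refutes that the change carries from one core to the other: the limit of > 20000 nM in this assay, at which 3 of the 4 values shown sit.

In this assay, on these data alone, compound 2 gives > 20000 nM, a limit of the assay and not a number, so the true size of the step stays unknown, and its printed floor alone does not establish a gain on this core.

The compounds shown leave open how a group other than these two five-membered aromatic rings, such as a phenyl ring, an aminomethyl group or a longer alkyl chain, would read at this place on the five-membered ring of the core. Also open, as far as these compounds go, is whether any such group would give a number on the core of compound 1, which a comparison of one change across the two cores would require.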